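The source may hold more compounds than are shown below. What is called first, only, known or untested is meant among the compounds shown, and "the series" means these compounds.

Working notes on the series. Compound 1 `CNC(=O)c1cc(Oc2ccc3nc(NC(=O)c4cc(Cl)cc(Cl)c4)sc3c2)ccn1` gives 9.62% in a functional assay on SK-BR-3 cells (Homo sapiens) for inhibition, read by MTT assay, with a stated time of 2 days, tested at 10 uM; on this read-out higher numbers stand for more inhibition of growth at the one concentration tested and lower numbers for less inhibition of growth. Going by the values given here, compound 2 `CNC(=O)c1cc(Oc2ccc3nc(NC(=O)Nc4ccc(Br)cc4)sc3c2)ccn1` gives 26.7% in this assay and stands highest of the two numbers measured so far; the one measured step, a number 17.1 percentage points higher from compound 1 to compound 2 (beyond the scatter), moves amide to urea and changes the halogen pattern on the outer ring at once. Compound 3 `CNC(=O)c1cc(Oc2ccc3nc(NC(=O)Nc4ccc(F)cc4)sc3c2)ccn1` keeps the urea of compound 2 and differs from it only by fluoro in place of bromo on an aromatic carbon. Among the compounds with values here, no measured step swaps one halogen for another on that ring, and the step from compound 1 to compound 2 bears on it only indirectly. The expectation for compound 3 is therefore a step of a number 4.7 percentage points lower from compound 2 to compound 3 (within the scatter), not beyond the scatter. Compound 3 is estimated at 22%, with a range from 5% to 40%.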

Compound 3, percent growth inhibition at one concentration: 14.2%
The estimate for compound 3 lay 7.8 percentage points above the measured number; the measured number falls inside the stated range.
By their numbers in this assay, from the lowest: compounds 1 and 3 (each within the scatter of the next); then compound 2.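

In this assay the halogen alone moves the number: with the urea held constant, fluoro in place of bromo on an aromatic carbon para to a large group gives a number 12.5 percentage points lower from compound 2 to compound 3 (beyond the scatter). The urea with 4-fluorophenyl does not separate from the amide with 3,5-dichlorophenyl, as the step reads a number 4.6 percentage points higher from compound 1 to compound 3 (within the scatter), so among these compounds the urea is clear of the amide only when it carries 4-bromophenyl, and the earlier step cannot be credited to the urea alone. Nothing available here explains the gap between bromo and fluoro.

As far as these compounds go, whether chloro, methyl or methoxy on this carbon would read closer to bromo or to fluoro remains open. From the compounds shown here alone, the contribution of the urea itself, apart from the halogen, also remains open.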